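A Shared Core, a New Link to the Carbonyl

A few compounds are considered here, and "the series" means these few. Any claim that something is new, unique, unknown or untested is made for them only; others in the source may bear on it.

Compound 1 `O=C(NC1CCNCC1)N1CCC(c2nc(-c3ccc4ccccc4n3)no2)CC1` gives 2500 nM in a functional assay on Shh Light II cells (Mus musculus) for inhibition, read by a luciferase reporter; a higher number here means a weaker inhibitor, a lower number a stronger inhibitor. Compound 2 `O=C(Nc1ncccc1Cl)N1CCC(c2nc(-c3ccc4ccccc4n3)no2)CC1` gives 2800 nM in this assay. Compound 3 `O=C(Nc1cccnc1Cl)N1CCC(c2nc(-c3ccc4ccccc4n3)no2)CC1` gives 1600 nM in this assay.

Compound 3 shows the lowest of the three numbers, yet the steps of a 1.6-fold lower number from compound 1 to compound 3 (0.19 log units; within the scatter) and a 1.8-fold lower number from compound 2 to compound 3 (0.24 log units; within the scatter) both stay within the scatter, so the three compounds cannot be ranked. Compound 4 `O=C(OCc1ccccc1)N1CCC(c2nc(-c3ccc4ccccc4n3)no2)CC1` differs from compound 3 in one place: benzyloxy in place of (2-chloropyridin-3-yl)amino on a carbonyl carbon. Going by the values given here, every measured step so far exchanged one group for another on the amide-type nitrogen, as in a 1.1-fold higher number from compound 1 to compound 2 (0.05 log units; within the scatter), and all three stayed within the scatter. Among the compounds with values here, no step replaces the (2-chloropyridin-3-yl)amino itself, so the data give no direct guide, only a record of small movements. Compound 4 is therefore expected to sit near compound 3, at an estimated 2500 nM, within 1000 nM to 6000 nM, an expected step of a 1.6-fold higher number from compound 3 to compound 4 (0.19 log units; within the scatter).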

Compound 4, half-maximal inhibitory concentration: > 2500 nM
Compound 4 was reported as a limit (the forecaster's own chance of this, stated with the estimate: 5%); the middle value sits exactly at the limit.
By their numbers in this assay, from the lowest: compounds 3, 1 and 2 (each within the scatter of the next).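

In this assay compound 4 is reported only as a limit, > 2500 nM. Going by these compounds alone, this is the first change at the carbonyl carbon itself: benzyloxy brings a carbon-only ring and no hydrogen-bond donor, giving an at least 1.5-fold higher number from compound 3 to compound 4 (0.19 log units; that floor lies within the scatter), so no real shift can be claimed. Benzyloxy in place of (piperidin-4-yl)amino gives a number no lower from compound 1 to compound 4 (the limit leaves the size open) on the same carbonyl carbon. The step from compound 2 to compound 4 cannot be read because the value of compound 4 is a limit: the limit of > 2500 nM in this assay, at which 1 of the 4 values shown sits.

From the compounds shown here alone, how far compound 4 truly lies from compound 3 stays open. Also open, going by these compounds, is whether the donor or the ring matters more, a question that phenylamino on the same carbonyl carbon could help separate.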